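The source may report more compounds than this note shows. Statements on the series, on what has been measured and on what is new or still open speak of the compounds shown alone.

Compound 1, `Cc1nc2ccccc2c(=O)n1/N=C/c1ccc(Oc2ccc(Br)cc2)cc1`, is the starting point. In a physicochemical assay for lipophilicity, in phosphate buffer, measured as octanol-water partition (a lower number here means a more polar compound, a higher number a more lipophilic compound), compound 1 gives 4.64, the lowest of the three numbers measured. Compound 2, `O=c1c2ccccc2nc(-c2ccccc2)n1/N=C/c1ccc(Oc2ccc(Br)cc2)cc1`, gives 6.39, and compound 3, `CCCc1nc2ccccc2c(=O)n1/N=C/c1ccc(Oc2ccc(Br)cc2)cc1`, gives 5.88. The measured steps are a number 1.75 log units higher from compound 1 to compound 2 (beyond the scatter), a number 1.24 log units higher from compound 1 to compound 3 (beyond the scatter) and a number 0.51 log units lower from compound 2 to compound 3 (beyond the scatter). All three of these steps alter the group on the shared core, and all three point the same way: a larger carbon-only group there gives a higher number.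

Compound 4, `Cc1nc2ccccc2c(=O)n1/N=C/c1ccc(Oc2ccc([N+](=O)[O-])cc2)cc1`, changes a different part of the molecule. The change from compound 1 is nitro in place of bromo on an aromatic carbon. For the measured compounds named here, none of the measured steps touches this ring, so no step bears directly on it; the measured steps only show how far a single substituent swap can move this assay. Since bromine leaves and a group counted with two hydrogen-bond acceptors enters, a step downward in this assay is expected, and the expected step is a number 1.04 log units lower from compound 1 to compound 4 (beyond the scatter). Compound 4 is therefore estimated at 3.6, with a range from 3 to 4.2.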

Compound 4, partition coefficient: 4.01
Estimate against measurement, compound 4: 0.41 log units below; the measured number falls inside the stated range.
By their numbers in this assay, from the lowest: compound 4; then compound 1; then compound 3; then compound 2.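

Nitro in place of bromo, on the aromatic carbon para to a large group, gives a number 0.63 log units lower from compound 1 to compound 4 (beyond the scatter) in this assay, so this part of the molecule can also shift the number, not only the group on the shared core. Compound 4 is the only compound shown that lies under compound 1, which makes this the one change here that moves the number downward from that starting point, whereas both changes to the group on the core moved it upward. Nothing measured here explains why this swap moves the number as it does.

Only one replacement at this position is shown, so it remains open whether an amine, a carboxylic acid or a plain hydrogen there would also lower the number. On these data alone, it is also open whether the same swap would give a step of similar size on compound 2 or compound 3, which carry phenyl and propyl on the core.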